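This account rests on a few compounds, and the source may have more. Where it says the series, first, only, none or still open, it means among the compounds named here.

Measured so far in an ADME assay on CCRF-CEM cells (Homo sapiens) for cytotoxicity, with a stated time of 72 h; a higher number here means a weaker inhibitor, a lower number a stronger inhibitor:
compound 1, `COc1ccc(-c2nc3sc(Cc4ccc(Cl)cc4)nn3c2C=O)cc1`: 3800 nM
compound 2, `Cc1ccc(-c2nc3sc(Cc4ccc(Cl)cc4)nn3c2C=O)cc1`: 17000 nM
compound 3, `COc1ccc(-c2nc3sc(Cc4ccc(Cl)cc4)nn3c2SC#N)cc1`: 10000 nM

Compound 4, `Cc1ccc(-c2nc3sc(Cc4ccc(Cl)cc4)nn3c2SC#N)cc1`, is not yet measured in this assay.

The two pairs share one change. Between compound 1 and compound 2 it reads methyl in place of methoxy on an aromatic carbon and gave a 4.5-fold higher number from compound 1 to compound 2 (0.65 log units; beyond the scatter). Between compound 3 and compound 4 it reads (methyl in place of methoxy on an aromatic carbon); the place lines of the two pairs agree word for word, so this is the same change on a different core. The cores differ as cyanosulfanyl in place of formyl on an aromatic carbon, a change which itself gave a 2.6-fold higher number from compound 1 to compound 3 (0.42 log units; beyond the scatter).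

Among the measured compounds shown here, with only one earlier instance of the methoxy-to-methyl change, the step from compound 3 to compound 4 is expected to fall in the same direction and of similar size, and the estimate is a 4.0-fold higher number from compound 3 to compound 4 (0.60 log units; beyond the scatter), resting on the earlier step of a 4.5-fold higher number from compound 1 to compound 2 (0.65 log units; beyond the scatter). Compound 4 is therefore expected to give about 40000 nM in this assay, likely between 15000 nM and 100000 nM.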

Compound 4, half-maximal inhibitory concentration: 22000 nM
For compound 4 the middle estimate is 1.8-fold (0.26 log units) above the measured one; the range from low to high includes it.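

In this assay, 4-methoxyphenyl to 4-methylphenyl on the cyanosulfanyl core gives a 2.2-fold higher number from compound 3 to compound 4 (0.34 log units; beyond the scatter), the same direction as on the formyl core, and the two steps do not differ beyond the scatter: the same change on two cores in this assay, a 4.5-fold higher number (0.65 log units; beyond the scatter) from compound 1 to compound 2 and a 2.2-fold higher number (0.34 log units; beyond the scatter) from compound 3 to compound 4, 2.0-fold (0.31 log units) apart, within the scatter of two such steps. Cyanosulfanyl in place of formyl on the 4-methylphenyl compounds gives a 1.3-fold higher number from compound 2 to compound 4 (0.11 log units; within the scatter), a step within the scatter that still does not differ beyond the scatter from its counterpart on the 4-methoxyphenyl compounds: the same change on two cores in this assay, a 2.6-fold higher number (0.42 log units; beyond the scatter) from compound 1 to compound 3 and a 1.3-fold higher number (0.11 log units; within the scatter) from compound 2 to compound 4, 2.0-fold (0.31 log units) apart, within the scatter of two such steps. The methoxy-to-methyl change therefore carries across these two cores, but two pairs do not show that it would carry to any other core, and they give no reason for the shift.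

Open, as far as these compounds go, is how an amine or a longer chain such as propoxy would behave in place of methoxy or methyl on that aromatic carbon. Also open, from the compounds shown here alone, is whether the change holds on a core with a carboxylic acid where formyl or cyanosulfanyl now stands.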